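Halogen swap on the benzyl ester of compound 2

The source may hold more compounds than are shown below. What is called first, only, known or untested is meant among the compounds shown, and "the series" means these compounds.

Among the measured compounds shown here, compound 2 `CC(C)(C)OC(=O)N[C@@H](CC(=O)OC1CCCC1)C(=O)OCc1ccc(Cl)cc1` and compound 1 `COc1ccc(CNC(=O)[C@H](CSCC2CCCC2)NC(=O)OC(C)(C)C)cc1` are the two measured members of this set. In a functional assay on IMR-32 cells for inhibition of Voltage-dependent N-type calcium channel subunit alpha-1B (Homo sapiens), read by calcium flux (on this read-out lower numbers stand for stronger inhibition and higher numbers for weaker inhibition), compound 1 gives 630 nM. In this assay compound 2 gives 3300 nM, the higher of the two numbers, and the gap to compound 1 lies beyond the scatter of repeated measurements. For the measured compounds named here, the two differ in more than one place, so no single-point step between measured compounds is available. Compound 3 `CC(C)(C)OC(=O)N[C@@H](CC(=O)OC1CCCC1)C(=O)OCc1ccc(Br)cc1` is the next member and is still to be measured. It differs from compound 2 by bromo in place of chloro on an aromatic carbon. Going by the values given here, no measured step of this kind exists, so the change is expected to stay within the scatter, with no clear direction in either sense. The step of a 1.1-fold lower number from compound 2 to compound 3 (0.04 log units; within the scatter) is the size expected. Compound 3 is therefore estimated at 3000 nM, within a range from 1200 nM to 8000 nM.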

Compound 3, half-maximal inhibitory concentration: 3400 nM
Compound 3: the middle estimate sits 1.1-fold (0.05 log units) below what was measured; the measured number falls inside the stated range.
By their numbers in this assay, from the lowest: compound 1; then compounds 2 and 3 (each within the scatter of the next).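

In this assay, the series now has its first single-point step: bromo in place of chloro on an aromatic carbon para to a large group gives a 1.0-fold higher number from compound 2 to compound 3 (0.01 log units; within the scatter). At this position, the read-out does not separate the 4-chlorobenzyl ester from the 4-bromobenzyl ester, so this exchange of one halogen for the other offers no handle on inhibition here. No measurement at hand offers a reason for this result.

From the compounds shown here alone, it remains open whether a non-halogen group on this carbon, such as methoxy, a nitrile or an aminomethyl group, would give a step beyond the scatter. Also open, going by these compounds, is how the number responds to changes elsewhere on the shared core, for example replacing the cyclopentyl ester with a longer chain or a carboxylic acid.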